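The source may report more compounds than this note shows. Statements on the series, on what has been measured and on what is new or still open speak of the compounds shown alone.

Compound 1 `COc1ccc(C2CC(c3ccccc3)=NN2C2=NC(=O)/C(=C3\C(=O)Nc4ccccc43)S2)cc1` and compound 2 `COc1ccc(C2CC(c3ccccc3)=NN2C2=NC(=O)/C(=C3\C(=O)Nc4ccc(Br)cc43)S2)cc1` share one core, while compound 3 `COc1ccc(C2=NN(C3=NC(=O)/C(=C4\C(=O)Nc5ccccc54)S3)C(c3ccc(Cl)cc3)C2)cc1` and compound 4 `COc1ccc(C2=NN(C3=NC(=O)/C(=C4\C(=O)Nc5ccc(Br)cc54)S3)C(c3ccc(Cl)cc3)C2)cc1` share another; the difference between the two cores is not broken down here. In a functional assay on cells (Cancer cell lines, Homo sapiens) for cytotoxicity, read by sulforhodamine B assay, with a stated time of 48 h (a lower number here means a stronger inhibitor of growth, a higher number a weaker inhibitor of growth), compound 1 gives 2020 nM, and compound 2 gives 200 nM. The change that separates them is bromo in place of hydrogen on an aromatic carbon and it produced a 10-fold lower number from compound 1 to compound 2 (1.00 log units; beyond the scatter). Compound 3 stands apart from both: in this assay compound 3 gives 100000 nM, the highest number among the three measured compounds, and its step to compound 1 as well as to compound 2 lies beyond the scatter.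

Compound 4 is related to compound 3 by bromo in place of hydrogen on an aromatic carbon, the same change that carried compound 1 to compound 2, and it is found twice among these compounds. Whether the shift it made on the core of compound 1 repeats on the core of compound 3 cannot be read from one example, so the expectation rests on the measured pair alone. He expects compound 4 to show a 6.7-fold lower number from compound 3 to compound 4 (0.82 log units; beyond the scatter) in this assay, a step of roughly the size seen from compound 1 to compound 2, because that pair gave a 10-fold lower number from compound 1 to compound 2 (1.00 log units; beyond the scatter), while allowing for a smaller shift since compound 3 begins so high. His estimate for compound 4 in this assay is therefore 15000 nM, expected to lie between 4000 nM and 100000 nM.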

Compound 4, concentration for 50% growth inhibition: 140 nM
Compound 4: the middle estimate sits 110-fold (2.03 log units) above what was measured; measured number outside the range, below it.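

On the core of compound 3, bromo in place of hydrogen on an aromatic carbon gave a 710-fold lower number from compound 3 to compound 4 (2.85 log units; beyond the scatter) in this assay, so the change lowered the number on both cores, though the two steps differ in size: the same change on two cores in this assay, a 10-fold lower number (1.00 log units; beyond the scatter) from compound 1 to compound 2 and a 710-fold lower number (2.85 log units; beyond the scatter) from compound 3 to compound 4, 71-fold (1.85 log units) apart, beyond the scatter of two such steps

In these two pairs the direction of the change carried from one core to the other, but its size did not, so the step measured on one core would have been a poor guide to the size of the step on the other. Two pairs show no general rule, and they do not show which part of the difference between the cores goes with the larger step, or why the steps differ, since that difference is not broken down here and nothing shown separates its parts.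

The compounds shown leave open whether a fluoro group, an amine or a carboxylic acid on the same aromatic carbon would lower the number on both cores as bromo does. They also leave open whether bromo would give a step nearer the smaller or the larger one on a third core, such as one carrying a fluoro group in place of the chloro group of compound 3.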